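The source may hold more compounds than are shown below. What is called first, only, known or untested is meant among the compounds shown, and "the series" means these compounds.

Measured compounds:
compound 1, `Cc1ccccc1CN1CCc2c(sc(NC(=O)c3ccccc3Cl)c2C(N)=O)C1`: in a functional assay on MKN-74 cells (Homo sapiens) for antiproliferative activity, with a stated time of 24 h (on this read-out lower numbers stand for stronger inhibition and higher numbers for weaker inhibition), compound 1 gives > 50000 nM
compound 2, `Cc1ccc(C(=O)Nc2sc3c(c2C(N)=O)CCN(Cc2c(Cl)cccc2Cl)C3)cc1`: in this assay compound 2 gives 12300 nM

The value for compound 1 is a limit of the assay, not a number. Compound 1 stands at the limit of > 50000 nM in this assay, at which 1 of the 2 values shown sits, so only an edge of the scale is known for it. Going by the values given here, compound 2 gives a number, but compound 2 differs from compound 1 in more than one place, so no step between the two can be drawn and its number only shows that a measurable value is possible on this core.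

Compound 3, `NC(=O)c1c(NC(=O)c2ccccc2Cl)sc2c1CCN(C(=O)Nc1c(Cl)cccc1Cl)C2`, is reached from compound 1 by one change: (2,6-dichlorophenyl)carbamoyl in place of 2-methylbenzyl on an amine nitrogen in a ring. Among the compounds with values here, there is no measured step to lean on here. With compound 1 known only as a limit, the step to compound 3 is expected to be small or absent beyond the scatter, with the direction left open, so an at least 1.4-fold lower number from compound 1 to compound 3 (0.15 log units; that floor lies within the scatter) is the expected outcome. Compound 3 is accordingly estimated at 35000 nM, in a range from 8000 nM to 150000 nM.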

Compound 3, half-maximal inhibitory concentration: 24400 nM
Compound 3: the middle estimate sits 1.4-fold (0.16 log units) above what was measured; measured number inside the range.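

Replacing 2-methylbenzyl with (2,6-dichlorophenyl)carbamoyl on the amine nitrogen in a ring gives an at least 2.0-fold lower number from compound 1 to compound 3 (0.31 log units; beyond the scatter). Going by these compounds alone, this is the first step that can be read on this core, and it shows that a change at this one position can move the number in this assay beyond the usual scatter. The step is only a minimum, and its true size stays unknown, because the value for compound 1 is a limit of the assay and not a number: the limit of > 50000 nM in this assay, at which 1 of the 3 values shown sits.

The change swaps a whole group at once, so the compounds shown do not separate the contribution of the carbamoyl link from that of the two chlorine atoms on the ring. Going by these compounds, it also stays open whether a different group on this nitrogen, such as a longer chain ending in an amine or a carboxylic acid, would push the number lower still or raise it again.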